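The compounds below may be only part of what the source reports. "The series", "measured", "known", "first", "only" and "open" are said of these compounds alone.

Compound 1 `Cn1cc(C2=C(c3nn(CCCn4cncn4)c4ncccc34)C(=O)N(c3ccccc3)C2=O)c2ccccc21`: > 100000 nM
Compound 2 `Cn1cc(C2=C(c3nn(CCCN4CCCCC4)c4ncccc34)C(=O)N(c3ccc(Cl)cc3)C2=O)c2ccccc21`: 28700 nM
Compound 3 `Cn1cc(C2=C(c3nn(CCn4ccnc4)c4ncccc34)C(=O)NC2=O)c2ccccc21`: > 100000 nM

These three compounds were tested in a functional assay on A549 cells (Homo sapiens) for antiproliferative activity, read by MTT assay, with a stated time of 48 h; on this read-out higher numbers stand for weaker inhibition and lower numbers for stronger inhibition. Compound 1 gives > 100000 nM, which is a limit and not a number. Compound 3 gives > 100000 nM, which is also a limit. Compound 2, at 28700 nM, is the only one of the three with an actual number, so it has no measured neighbour for direct comparison.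

Compound 4 `COc1ccc(N2C(=O)C(c3cn(C)c4ccccc34)=C(c3nn(CCCN4CCCCC4)c4ncccc34)C2=O)cc1` has yet to be measured. It differs from compound 2 in a single place, where a 4-chlorophenyl becomes a 4-methoxyphenyl: methoxy in place of chloro on an aromatic carbon. This is methoxy in place of chloro on an aromatic carbon, para to a large group. Among the compounds with values here, no measured pair shows this swap, so the data give no size for it. The expectation in this assay is therefore no step beyond the usual scatter, anchored on compound 2 at 28700 nM. The expected change is a 1.1-fold higher number from compound 2 to compound 4 (0.05 log units; within the scatter). Compound 4 is estimated at 32000 nM, with an expected range of 12000 nM to 90000 nM.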

Compound 4, half-maximal inhibitory concentration: 30300 nM
Compound 4: middle estimate off by 1.1-fold (0.02 log units), on the high side; the range from low to high includes it.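

In this assay, replacing the 4-chlorophenyl with a 4-methoxyphenyl gives a 1.1-fold higher number from compound 2 to compound 4 (0.02 log units; within the scatter). Within the data shown here, this is the first measured pair that differs in one place, so it gives the first size for any change at this position, which the earlier compounds could not provide. With the rest of the molecule held fixed, chloro and methoxy cannot be told apart on this read-out, even though methoxy brings a hydrogen-bond acceptor that chloro lacks.

On these data alone, whether an amine or a carboxylic acid on the same aromatic carbon would also stay within the scatter remains open. Steps involving compound 1 and compound 3 cannot be read, so they say nothing about how far this position tolerates change: the limit of > 100000 nM in this assay, at which 2 of the 4 values shown sit.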